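The source may hold more compounds than are shown below. What is called first, only, known or untested is meant among the compounds shown, and "the series" means these compounds.

In a functional assay on DU-145 cells (Homo sapiens) for inhibition, read by trypan blue exclusion, with a stated time of 96 h (a higher number here means a weaker inhibitor of growth, a lower number a stronger inhibitor of growth), compound 1 (`COc1ccccc1/C=C(\C(=O)c1ccc(Cl)cc1)S(=O)(=O)Cc1ccc(Cl)cc1`) gives 25000 nM and compound 2 (`Cc1ccc(C)c(/C=C(\C(=O)c2ccc(Cl)cc2)S(=O)(=O)Cc2ccc(Cl)cc2)c1`) gives 10000 nM, the lower of the two numbers. Compound 3 (`Cc1ccsc1/C=C(\C(=O)c1ccc(Cl)cc1)S(=O)(=O)Cc1ccc(Cl)cc1`) carries 3-methylthiophen-2-yl in place of 2,5-dimethylphenyl on a double-bonded chain carbon bound to a double-bonded chain carbon. Going by the values given here, only one measured step bears on this place, a 2.5-fold lower number from compound 1 to compound 2 (0.40 log units; beyond the scatter), and it is modest. Among the compounds with values here, no measured compound carries the entering group, so no firm direction can be expected. The estimated step, a 1.2-fold higher number from compound 2 to compound 3 (0.08 log units; within the scatter), is expected to stay within the scatter. Compound 3 is expected near 12000 nM, with an estimated range of 4000 nM to 35000 nM.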

Compound 3, concentration for 50% growth inhibition: 25000 nM
Compound 3: the middle estimate sits 2.1-fold (0.32 log units) below what was measured, within the range that was stated.
By their numbers in this assay, from the lowest: compound 2; then compounds 1 and 3 (each within the scatter of the next).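

In this assay, 3-methylthiophen-2-yl in place of 2,5-dimethylphenyl gives a 2.5-fold higher number from compound 2 to compound 3 (0.40 log units; beyond the scatter) and in place of 2-methoxyphenyl gives no change at the digits printed from compound 1 to compound 3 (within the scatter) at this place, on a double-bonded chain carbon bound to a double-bonded chain carbon. Among these three groups, 2,5-dimethylphenyl alone stands apart, with the lowest number, while 3-methylthiophen-2-yl and 2-methoxyphenyl cannot be told apart. Nothing at hand explains this difference. Going by these compounds, whether a group bearing an amine or a carboxylic acid at this place would move the number remains open.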